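The compounds below may be only part of what the source reports. "The series", "measured", "known", "first", "only" and "open" are said of these compounds alone.

Measured in a functional assay on HeLa cells (Homo sapiens) for inhibition, read by CCK-8 assay, with a stated time of 48 h; on this read-out lower numbers stand for stronger inhibition and higher numbers for weaker inhibition:
- compound 1 `COc1cc(-c2ccnc3cc(-c4ccc(Cl)cc4)nn23)cc(OC)c1OC` gives 1490 nM
- compound 2 `COc1cc(-c2ccnc3cc(-c4ccc(C(C)=O)cc4)nn23)cc(OC)c1OC` gives 1810 nM

Compound 2 stands within the scatter of compound 1, so the two mark a single level and no order. Next comes compound 3 `COc1cc(-c2ccnc3cc(-c4ccc5cnn(C)c5c4)nn23)cc(OC)c1OC`, with the change (1-methyl-1H-indazol-6-yl in place of 4-acetylphenyl on an aromatic carbon), which puts 1-methyl-1H-indazol-6-yl in place of 4-acetylphenyl on an aromatic carbon. For the measured compounds named here, only one measured step bears on this: a 1.2-fold higher number from compound 1 to compound 2 (0.08 log units; within the scatter), with acetyl in place of chloro on an aromatic carbon. That step exchanges a single substituent, whereas the new change replaces the whole aryl group, so it is a weak guide. Going by the values given here, no measured compound carries a fused group here. A move to a lower number in this assay is expected, with low confidence. The estimated change is a 4.5-fold lower number from compound 2 to compound 3 (0.66 log units; beyond the scatter). For compound 3 the expected value is 400 nM, with an estimated range from 30 nM to 2500 nM.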

Compound 3, half-maximal inhibitory concentration: 97 nM
The estimate for compound 3 lay 4.1-fold (0.62 log units) above the measured number; the measured number falls inside the stated range.
By their numbers in this assay, from the lowest: compound 3; then compounds 1 and 2 (each within the scatter of the next).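

Replacing the whole aryl group on this aromatic carbon of the five-membered aromatic ring with 2 nitrogen changes the result in this assay far more than the earlier substituent exchange (a 1.2-fold higher number from compound 1 to compound 2 (0.08 log units; within the scatter)), with 1-methyl-1H-indazol-6-yl giving a 19-fold lower number from compound 2 to compound 3 (1.27 log units; beyond the scatter) and also a 15-fold lower number from compound 1 to compound 3 (1.19 log units; beyond the scatter). Since compound 1 and compound 2 form one level, both large steps describe a single drop from that level, and the fused group is the first change shown here to leave it. Nothing available explains this drop.

On these data alone, the change brings in a second ring, ring nitrogens and a methyl group together, so their separate contributions remain open. As far as these compounds go, an indazole without the methyl group, an indole or a naphthalene at this position would begin to separate them, and whether other attachment points on the indazole hold the result also remains open.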